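This account rests on a few compounds, and the source may have more. Where it says the series, first, only, none or still open, it means among the compounds named here.

Compound 3 `CC1CCN(S(=O)(=O)N2CCN(CC(=O)Nc3cccc(F)c3)CC2)CC1` carries a 3-fluorophenyl group on an amide-type nitrogen of the shared core. In an assay on HEK293 cells for activation of potassium channel subfamily T member 1 (Homo sapiens), read by thallium flux (a higher number here means that more compound is needed for the effect, a lower number that less compound is needed), compound 3 gives 4600 nM, the lowest of the two plain numbers available. Its nearest neighbour is compound 1 `CC1CCN(S(=O)(=O)N2CCN(CC(=O)Nc3cccc(Cl)c3)CC2)CC1`, which in this assay gives 7600 nM; the step of a 1.7-fold lower number from compound 1 to compound 3 (0.22 log units; within the scatter) sits within the scatter, so these two cannot be ranked. Compound 2 `CC1CCN(S(=O)(=O)N2CCN(CC(=O)Nc3ccc(Cl)cc3)CC2)CC1` is reported in this assay only as a limit, > 10000 nM, and not as a number (the limit of > 10000 nM in this assay, at which 1 of the 3 values shown sits). For the measured compounds named here, the step of an at least 1.3-fold higher number from compound 1 to compound 2 (0.11 log units; that floor lies within the scatter) therefore reads as a floor, while an at least 2.1-fold lower number from compound 2 to compound 3 (0.33 log units; beyond the scatter) is the one step in the set that stands beyond the scatter.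

Compound 4 `CC1CCN(S(=O)(=O)N2CCN(CC(=O)Nc3ccccc3F)CC2)CC1` differs from compound 3 in one place: 2-fluorophenyl in place of 3-fluorophenyl on an amide-type nitrogen. Going by the values given here, none of the measured steps places a halogen at this position; the closest comparison is the shift of chlorine between two positions in an at least 1.3-fold higher number from compound 1 to compound 2 (0.11 log units; that floor lies within the scatter), a floor that is within the scatter. A step of at most modest size, in either direction or none beyond the scatter, is therefore expected in this assay. Compound 4 is estimated at 6000 nM, within 2500 nM to 20000 nM, which corresponds to an expected 1.3-fold higher number from compound 3 to compound 4 (0.12 log units; within the scatter).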

Compound 4, half-maximal effective concentration: > 10000 nM
Compound 4: a limit, no number; the forecaster's own chance of this, stated with the estimate: 30%; at least 1.6-fold (0.22 log units) between middle value and limit.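

Replacing 3-fluorophenyl with 2-fluorophenyl on the amide-type nitrogen keeps the same atoms and gives an at least 2.1-fold higher number from compound 3 to compound 4 (0.33 log units; beyond the scatter) in this assay, so moving this halogen alone now produces a step beyond the scatter. The earlier move of chlorine gave only an at least 1.3-fold higher number from compound 1 to compound 2 (0.11 log units; that floor lies within the scatter), a floor that could not show whether halogen placement on this ring mattered in this series. The comparison with the chloro compound is also only a floor, an at least 1.3-fold higher number from compound 1 to compound 4 (0.11 log units; that floor lies within the scatter), and the step between compound 2 and compound 4 cannot be read, as both are reported only as limits: the limit of > 10000 nM in this assay, at which 2 of the 4 values shown sit.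

From the compounds shown here alone, how far compound 4 lies past its limit remains open, so the 2-fluorophenyl and 4-chlorophenyl groups cannot be ranked against each other. The compounds shown also leave open whether 2-chlorophenyl, 4-fluorophenyl or unsubstituted phenyl would fall with compound 3 or at the limit, and whether a methoxy group or a nitrile on the ring would give a lower number than the 3-fluorophenyl group does.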